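A few compounds are considered here, and "the series" means these few. Any claim that something is new, unique, unknown or untested is made for them only; others in the source may bear on it.

Compound 1 `Cc1cc(NC(=O)Nc2ccccc2OC(F)(F)F)c2ccccc2n1`: > 25000 nM
Compound 2 `Cc1cc(NC(=O)Nc2ccccc2N)c2ccccc2n1`: > 25000 nM
Compound 3 `COc1ccccc1NC(=O)Nc1cc(C)nc2ccccc12`: > 25000 nM

These three results come from an ADME assay on Raji cells (Homo sapiens) for cytotoxicity, with a stated time of 72 h (a higher number here means that more compound is needed for the effect, a lower number that less compound is needed), and each one is a limit, not a number. Compound 2 therefore has no exact position, only > 25000 nM, and it shares that position with the others: the limit of > 25000 nM in this assay, at which 3 of the 3 values shown sit.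

Compound 4 `Cc1cc(NC(=O)Nc2cccnc2)c2ccccc2n1` has not yet been measured. It differs from compound 2 in one place: pyridin-3-yl in place of 2-aminophenyl on an amide-type nitrogen. In words, pyridin-3-yl stands in place of 2-aminophenyl on an amide-type nitrogen.

Among the compounds with values here, three measured steps bear on this change, since each swaps a group in the same part of the molecule: a step that the two limits leave unreadable from compound 1 to compound 2, a step that the two limits leave unreadable from compound 1 to compound 3 and a step that the two limits leave unreadable from compound 2 to compound 3. None has a readable size, and none replaces the whole ring as compound 4 does, so they offer no size to carry over. The expectation therefore rests on compound 2 and its limit of > 25000 nM.

No step beyond the usual scatter is expected in this assay, in either direction, and the expected change is a number no higher from compound 2 to compound 4 (the limit leaves the size open). A report of only a limit is the likeliest outcome. For compound 4 the estimated value is 25000 nM, with an expected range from 12000 nM to 50000 nM.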

Compound 4, half-maximal effective concentration: > 25000 nM
Compound 4 ended at the assay's limit; the forecaster's own chance of this, stated with the estimate: 85%; the middle value lies on the limit itself.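

In this assay compound 4 gives > 25000 nM, which is a limit and not a number. Compound 2 also stands at a limit, so no size can be read for the change from compound 2 to compound 4: the limit of > 25000 nM in this assay, at which 4 of the 4 values shown sit.

The compounds shown leave open how much of each is needed for the effect, and whether swapping the group on the amide-type nitrogen changes that amount.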